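Bromo to Methoxy: Expecting Compound 4

The source may report more compounds than this note shows. Statements on the series, on what has been measured and on what is new or still open speak of the compounds shown alone.

Compound 1 `Cn1cc(C2CC(c3ccc(Br)cc3)=NN2C(=O)c2cccnc2)c2cc(Br)ccc21` and compound 2 `COc1ccc(C2=NN(C(=O)c3cccnc3)C(c3cn(C)c4ccc(Br)cc34)C2)cc1` share one core, while compound 3 `COc1ccc2c(c1)c(C1CC(c3ccc(Br)cc3)=NN1C(=O)c1ccc(OC)nc1)cn2C` and compound 4 `COc1ccc(C2=NN(C(=O)c3ccc(OC)nc3)C(c3cn(C)c4ccc(OC)cc34)C2)cc1` share another; the difference between the two cores is not broken down here. In a functional assay on HepG2 cells (Homo sapiens) for inhibition, read by MTT assay, with a stated time of 48 h (on this read-out higher numbers stand for weaker inhibition of growth and lower numbers for stronger inhibition of growth), compound 1 gives 6910 nM. Compound 2 gives 540 nM in this assay. The change methoxy in place of bromo on an aromatic carbon thus produced a 13-fold lower number from compound 1 to compound 2 (1.11 log units; beyond the scatter). For compound 3 this assay reports only a limit, > 10000 nM, which is the limit of > 10000 nM in this assay, at which 1 of the 3 values shown sits. Compound 4 carries the same change, (methoxy in place of bromo on an aromatic carbon). Because the earlier change brought a 13-fold lower number from compound 1 to compound 2 (1.11 log units; beyond the scatter), a step of similar size is expected here, an at least 3.3-fold lower number from compound 3 to compound 4 (0.52 log units; beyond the scatter), although the starting point is uncertain since compound 3 is known only as a limit. Compound 4 is estimated at 3000 nM, within a range from 800 nM to 12000 nM.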

Compound 4, concentration for 50% growth inhibition: 230 nM
For compound 4 the middle estimate is 13-fold (1.12 log units) above the measured one; the measured number lies below the stated range.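

In this assay, methoxy in place of bromo gave an at least 43-fold lower number from compound 3 to compound 4 (1.63 log units; beyond the scatter), so on the second core the change ran in the same direction as on the first, but its size did not simply carry over: the same change on two cores in this assay, a 13-fold lower number (1.11 log units; beyond the scatter) from compound 1 to compound 2 and an at least 43-fold lower number (1.63 log units; beyond the scatter) from compound 3 to compound 4, at least 3.3-fold (0.53 log units) apart, beyond the scatter of two such steps. Going by these compounds, compound 3 is known only as a limit, > 10000 nM, so the true size of the second step stays unknown. Two cores show neither how the change would behave on a further core nor why the two steps differ.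

The compounds shown leave open whether another group at this place, such as an amine, a carboxylic acid or a longer alkoxy chain, would lower the number as methoxy does. They also leave open which of the differences between the two cores sets the size of the step.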